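Heteroaryl sulfonamides on a shared thiourea core

The compounds below may be only part of what the source reports. "The series", "measured", "known", "first", "only" and "open" are said of these compounds alone.

Measured so far in a functional assay on AS49-RAW cells (Homo sapiens) for antiproliferative activity, read by sulforhodamine B assay, with a stated time of 48 h; a lower number here means a stronger inhibitor, a higher number a weaker inhibitor:
compound 1 `CC(=O)NS(=O)(=O)c1ccc(N/C(S)=N\c2ccnc3cc(C(F)(F)F)ccc23)cc1` — 37600 nM
compound 2 `O=S(=O)(Nc1nccs1)c1ccc(N/C(S)=N\c2ccnc3cc(C(F)(F)F)ccc23)cc1` — 27200 nM
compound 3 `O=S(=O)(Nc1ccccn1)c1ccc(N/C(S)=N\c2ccnc3cc(C(F)(F)F)ccc23)cc1` — 33500 nM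

Among the three numbers compound 1 gives the highest, but the steps of a 1.1-fold lower number from compound 1 to compound 3 (0.05 log units; within the scatter) and a 1.4-fold lower number from compound 1 to compound 2 (0.14 log units; within the scatter) both lie within the scatter, as does a 1.2-fold higher number from compound 2 to compound 3 (0.09 log units; within the scatter). Compound 4 `Cc1ccnc(NS(=O)(=O)c2ccc(N/C(S)=N\c3ccnc4cc(C(F)(F)F)ccc34)cc2)n1` carries the change (4-methylpyrimidin-2-yl in place of acetyl on a sulfonamide nitrogen). The two measured steps that bear on it, a 1.4-fold lower number from compound 1 to compound 2 (0.14 log units; within the scatter) and a 1.1-fold lower number from compound 1 to compound 3 (0.05 log units; within the scatter), each put a six- or five-membered heteroaryl group in place of acetyl at the same sulfonamide nitrogen and neither moved the number beyond the scatter. Compound 4 is therefore expected to show no step beyond the scatter, a 1.3-fold lower number from compound 1 to compound 4 (0.10 log units; within the scatter). The estimate for compound 4 in this assay is 30000 nM, with a range from 14000 nM to 65000 nM.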

Compound 4, half-maximal inhibitory concentration: 31000 nM
Estimate against measurement, compound 4: 1.0-fold (0.01 log units) below; the measured number falls inside the stated range.
By their numbers in this assay, from the lowest: compounds 2, 4, 3 and 1 (each within the scatter of the next).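

In this assay, a six-membered aromatic ring with 2 hetero atoms and a methyl group at this sulfonamide nitrogen stays within the scatter of acetyl (a 1.2-fold lower number from compound 1 to compound 4 (0.08 log units; within the scatter)), of pyridin-2-yl (a 1.1-fold lower number from compound 3 to compound 4 (0.03 log units; within the scatter)) and of 1,3-thiazol-2-yl (a 1.1-fold higher number from compound 2 to compound 4 (0.06 log units; within the scatter)). All four groups at this nitrogen therefore give numbers within the scatter of one another, and the methylated ring adds no step beyond it. No measured evidence bears on this result. The compounds shown leave open whether an amine, a carboxylic acid or a longer chain on this nitrogen would move the number beyond the scatter.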